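Methoxy added to the second phenyl of compound 2

The source may report more compounds than this note shows. Statements on the series, on what has been measured and on what is new or still open speak of the compounds shown alone.

Compound 1 `O=C1N=C(N2N=C(c3ccccc3)CC2c2ccccc2O)S/C1=C1/C(=O)Nc2ccccc21` gives 4400 nM in a functional assay on cells (Melanoma cell, Homo sapiens) for cytotoxicity, read by sulforhodamine B assay, with a stated time of 48 h; on this read-out higher numbers stand for weaker inhibition of growth and lower numbers for stronger inhibition of growth. Compound 2 `COc1ccc(C2CC(c3ccccc3)=NN2C2=NC(=O)/C(=C3\C(=O)Nc4ccccc43)S2)cc1` gives 4510 nM. Compound 3 `COc1ccc(C2CC(c3ccccc3)=NN2C2=NC(=O)/C(=C3\C(=O)Nc4ccc(Br)cc43)S2)cc1` gives 550 nM.

Among these three numbers compound 2 stands highest, but its nearest neighbour compound 1 lies within the scatter of it, a 1.0-fold higher number from compound 1 to compound 2 (0.01 log units; within the scatter), while compound 3 lies well apart, an 8.2-fold lower number from compound 2 to compound 3 (0.91 log units; beyond the scatter). Compound 4 `COc1ccc(C2=NN(C3=NC(=O)/C(=C4\C(=O)Nc5ccccc54)S3)C(c3ccc(OC)cc3)C2)cc1` differs from compound 2 by methoxy in place of hydrogen on an aromatic carbon. Among the measured compounds shown here, the step that bears most directly on this change is the one from compound 1 to compound 2, where a methoxy-bearing phenyl was introduced on the saturated ring carbon without effect beyond the scatter. The step from compound 2 to compound 3 concerns a bromo on a different ring and offers no guidance for a methoxy on the phenyl in question. For the measured compounds named here, no measured step therefore supports a change beyond the scatter in this assay, and compound 4 is expected to show a 1.0-fold lower number from compound 2 to compound 4 (0.00 log units; within the scatter). The value of compound 4 in this assay is estimated at 4500 nM, within a range from 1800 nM to 11000 nM.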

Compound 4, concentration for total growth inhibition: 100000 nM
Estimate against measurement, compound 4: 22-fold (1.35 log units) below; the measured number lies above the stated range.
By their numbers in this assay, from the lowest: compound 3; then compounds 1 and 2 (each within the scatter of the next); then compound 4.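

Among the compounds shown here, the phenyl on the carbon of the ring double bond proved far more sensitive in this assay than the earlier compounds could show: going from phenyl to 4-methoxyphenyl there gives a 22-fold higher number from compound 2 to compound 4 (1.35 log units; beyond the scatter). The earlier steps shown here touched other places, and a 4-methoxyphenyl on the saturated ring carbon, in place of 2-hydroxyphenyl, gave only a 1.0-fold higher number from compound 1 to compound 2 (0.01 log units; within the scatter), so the same group reads very differently at the two places. No measurement shown here accounts for this rise in the number.

The compounds shown leave open whether the rise belongs to methoxy itself or would follow any group at this place, such as a fluoro, a hydroxyl or an amine. They also leave open whether the bromo of compound 3 would still lower the number with this 4-methoxyphenyl present.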